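Working notes: a dimethylphenyl swap in the series

The source may hold more compounds than are shown below. What is called first, only, known or untested is meant among the compounds shown, and "the series" means these compounds.

In an ADME assay on C8166 cells (Homo sapiens) for cytotoxicity, read by MTT assay (on this read-out lower numbers stand for higher toxicity in this test and higher numbers for lower toxicity in this test), compound 1 (`Cc1cc(S(N)(=O)=O)ccc1NC(=O)COc1ccc(Cl)cc1C(O)c1ccccc1C`) gives 33900 nM and compound 2 (`Cc1cccc(C(O)c2cc(Cl)ccc2OCC(=O)Nc2ccc(S(N)(=O)=O)cc2C)c1`) gives 33200 nM while compound 3 (`Cc1ccc(C(O)c2cc(Cl)ccc2OCC(=O)Nc2ccc(S(N)(=O)=O)cc2C)c(C)c1`) gives 26400 nM as its number. Compound 3 therefore stands level with the other two: neither the step (a 1.3-fold lower number from compound 1 to compound 3 (0.11 log units; within the scatter)) nor the step (a 1.3-fold lower number from compound 2 to compound 3 (0.10 log units; within the scatter)) separates it from them.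

Compound 4 (`Cc1ccc(C)c(C(O)c2cc(Cl)ccc2OCC(=O)Nc2ccc(S(N)(=O)=O)cc2C)c1`) has the same atoms as compound 3, joined differently. It carries 2,5-dimethylphenyl in place of 2,4-dimethylphenyl on a saturated chain carbon bound to an aromatic carbon and an oxygen on a saturated carbon.

Among the measured compounds shown here, two measured steps bear most directly on this change, as both exchange one substituted phenyl for another at that same place. These are the step (a 1.0-fold lower number from compound 1 to compound 2 (0.01 log units; within the scatter)) and the step (a 1.3-fold lower number from compound 2 to compound 3 (0.10 log units; within the scatter)), and neither goes beyond the scatter. For the measured compounds named here, no compound measured so far goes against this flat picture, although three compounds are a narrow base and none of them carries the 2,5-dimethylphenyl group.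

In this assay the expected step is small and stays within the scatter (a 1.1-fold higher number from compound 3 to compound 4 (0.04 log units; within the scatter)). For compound 4 the estimated value is 29000 nM with an expected range (17000 nM to 50000 nM).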

Compound 4, half-maximal cytotoxic concentration: 35500 nM
Estimate against measurement, compound 4: 1.2-fold (0.09 log units) below; the range from low to high includes it.
By their numbers in this assay, from the lowest: compounds 3, 2, 1 and 4 (each within the scatter of the next).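

In this assay, among the compounds shown here, 2,5-dimethylphenyl in place of 2,4-dimethylphenyl on a saturated chain carbon bound to an aromatic carbon and an oxygen on a saturated carbon gives a 1.3-fold higher number from compound 3 to compound 4 (0.13 log units; within the scatter), so these two isomeric groups cannot be told apart in this test, a comparison the earlier compounds, with only one dimethylphenyl group among them, could not offer. Compound 4 also cannot be told apart from the 3-methylphenyl and 2-methylphenyl compounds, with a 1.1-fold higher number from compound 2 to compound 4 (0.03 log units; within the scatter) and a 1.0-fold higher number from compound 1 to compound 4 (0.02 log units; within the scatter). Methyl in place of hydrogen on an aromatic carbon thus reads alike from two different starting compounds, and the four compounds stay flat at this place: the same change on two cores in this assay, a 1.3-fold lower number (0.11 log units; within the scatter) from compound 1 to compound 3 and a 1.1-fold higher number (0.03 log units; within the scatter) from compound 2 to compound 4, 1.4-fold (0.14 log units) apart, within the scatter of two such steps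

All four groups at this place are methyl-substituted phenyl rings, so the flat picture says nothing about a group of another kind there, such as an amine, a carboxylic acid or a longer chain. Going by these compounds, only cytotoxicity is read here, and whether these isomers would separate in any other test remains open.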